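Chlorophenyl to Chloropyridinyl on a Piperazine Amide

The compounds below may be only part of what the source reports. "The series", "measured", "known", "first", "only" and "open" are said of these compounds alone.

compound 1 `O=C(COCc1ccccc1)N1CCN(c2ccccc2)CC1` — 7100 nM
compound 2 `O=C(COCc1ccccc1)N1CCN(c2ccc(Cl)cc2)CC1` — 350 nM

In a functional assay on HEK293 cells for positive allosteric modulation of metabotropic glutamate receptor 5 (Homo sapiens), read by FLIPR and calcium flux (a higher number here means that more compound is needed for the effect, a lower number that less compound is needed), compound 2 gives 350 nM, the lowest of the two numbers, while compound 1 gives 7100 nM. Among the compounds with values here, the single measured step, a 20-fold lower number from compound 1 to compound 2 (1.31 log units; beyond the scatter), concerns chloro in place of hydrogen on an aromatic carbon. Compound 3 `O=C(COCc1ccccc1)N1CCN(c2cc(Cl)ccn2)CC1` differs from compound 2 by 4-chloropyridin-2-yl in place of 4-chlorophenyl on an amine nitrogen in a ring. Within the data shown here, no measured step touches an exchange of this kind, and the chloro is kept, so there is no direct guide. Compound 3 is therefore expected at 700 nM, with a range of 200 nM to 2500 nM. This estimate means a step of a 2.0-fold higher number from compound 2 to compound 3 (0.30 log units; within the scatter), expected to remain modest.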

Compound 3, half-maximal effective concentration: 570 nM
Beside the measured number, compound 3's estimate is 1.2-fold (0.09 log units) above it; low and high end bracket the measured number.
By their numbers in this assay, from the lowest: compounds 2 and 3 (each within the scatter of the next); then compound 1.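

Putting 4-chloropyridin-2-yl in place of 4-chlorophenyl on the ring amine nitrogen gives in this assay a 1.6-fold higher number from compound 2 to compound 3 (0.21 log units; within the scatter) and so shows that this aromatic ring accepts a ring nitrogen, with its one hydrogen-bond acceptor, without a clear loss. The large step seen with chloro also holds in the pyridine series, with a 12-fold lower number from compound 1 to compound 3 (1.10 log units; beyond the scatter) against the plain phenyl. No evidence at hand explains this tolerance.

From the compounds shown here alone, whether an unsubstituted pyridin-2-yl would keep any of this gain stays open. So does whether methyl or trifluoromethyl could stand in for the chloro on the pyridine ring.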